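Replacing the Group on the Ring Amine of Compound 2

A few compounds are considered here, and "the series" means these few. Any claim that something is new, unique, unknown or untested is made for them only; others in the source may bear on it.

Of the compounds shown here, two have so far been tested in an ADME assay on HEK-293T cells (Homo sapiens) for cytotoxicity, read by CCK-8 assay, with a stated time of 48 h; a lower number here means a stronger inhibitor, a higher number a weaker inhibitor. Compound 1 (`COc1ccc(Oc2ccc([N+](=O)[O-])cc2-c2ccsc2S(=O)(=O)N2CCN(C(=S)Nc3ccc(Cl)cc3)CC2)cc1OC`) gives > 50000 nM, which is a limit of the assay and not a number. Compound 2 (`COc1ccc(Oc2ccccc2-c2ccsc2S(=O)(=O)N2CCN(C(=O)Nc3cccc([N+](=O)[O-])c3)CC2)cc1OC`) gives > 20000 nM, which is also a limit. Among the measured compounds shown here, compound 2 therefore has no exact position on the scale, and no measured step connects it to compound 1.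

Compound 3 (`COc1ccc(Oc2ccccc2-c2ccsc2S(=O)(=O)N2CCN(C(=S)Nc3ccc(Cl)cc3)CC2)cc1OC`) has not yet been measured. It differs from compound 2 in one place, on an amine nitrogen in a ring, where the (3-nitrophenyl)carbamoyl group leaves: a group of 10 heavy atoms (7 carbon, 1 nitrogen, 1 sulfur, 1 chlorine; one six-membered aromatic ring of carbon only) in place of a group of 12 heavy atoms (7 carbon, 2 nitrogen, 3 oxygen; one six-membered aromatic ring of carbon only), on an amine nitrogen in a ring. For the measured compounds named here, no measured step shows what such a change does in this assay, so the expectation is for no change beyond the usual scatter, in neither direction. The estimated step is a step that the limit leaves unreadable from compound 2 to compound 3. This expectation rests on compound 2 and its limit of > 20000 nM, and compound 3 may well return only a limit too. For compound 3, the estimated value is 30000 nM, with an expected range from 12000 nM to 70000 nM.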

Compound 3, half-maximal inhibitory concentration: > 20000 nM
Compound 3: no number, only a limit; the forecaster's own chance of this, stated with the estimate: 75%; the middle value does not contradict the limit.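

Among the compounds shown here, compound 1, compound 2 and compound 3 all return only limits in this assay, and no step from compound 2 to compound 3 or from compound 1 to compound 3 can be read. Left open is whether the change of group on the ring amine, or hydrogen in place of nitro, shifts the value in this assay at all.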